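A Bulkier Amine Group on the Shared Core

The compounds below may be only part of what the source reports. "The series", "measured", "known", "first", "only" and "open" are said of these compounds alone.

Among the compounds with values here, compound 2 `CNCC(=O)N1N=C(c2cc3ccccc3oc2=O)CC1c1ccccc1` gives 2300 nM in a functional assay on PC-3 cells (Homo sapiens) for cytotoxicity, read by MTT assay, with a stated time of 48 h (on this read-out lower numbers stand for stronger inhibition and higher numbers for weaker inhibition), the lowest of the two numbers measured so far. Its nearest neighbour, compound 1 `O=C(c1ccccc1)N1N=C(c2cc3ccccc3oc2=O)CC1c1ccccc1`, gives 5870 nM in this assay, and the step of a 2.6-fold lower number from compound 1 to compound 2 (0.41 log units; beyond the scatter) lies beyond the scatter. Compound 3 `CC(C)(C)NCC(=O)N1N=C(c2cc3ccccc3oc2=O)CC1c1ccccc1` has not yet been measured in this assay. It differs from compound 2 by tert-butyl in place of methyl on an amine nitrogen, a tert-butyl in place of methyl on an amine nitrogen whose other neighbour is a saturated chain carbon. Within the data shown here, only one measured step exists, a 2.6-fold lower number from compound 1 to compound 2 (0.41 log units; beyond the scatter), and it concerns a change at the carbonyl carbon, not at the amine nitrogen, so no measured step bears on the present change directly. With nothing to lean on, the step of a 1.1-fold higher number from compound 2 to compound 3 (0.04 log units; within the scatter) is expected to stay within the scatter. Compound 3 is therefore estimated at 2500 nM, with a range from 1000 nM to 6500 nM.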

Compound 3, half-maximal inhibitory concentration: 16400 nM
Compound 3: middle estimate off by 6.6-fold (0.82 log units), on the low side; the measured number lies above the stated range.
By their numbers in this assay, from the lowest: compound 2; then compound 1; then compound 3.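

In this assay, the amine nitrogen proves sensitive to what it carries: tert-butyl in place of methyl, 4 heavy atoms instead of 1, gives a 7.1-fold higher number from compound 2 to compound 3 (0.85 log units; beyond the scatter). The swap at the carbonyl carbon also turns out to depend on that substituent, since ((tert-butyl)amino)methyl in place of phenyl gives a 2.8-fold higher number from compound 1 to compound 3 (0.45 log units; beyond the scatter), while (methylamino)methyl in the same place gave a 2.6-fold lower number from compound 1 to compound 2 (0.41 log units; beyond the scatter), the opposite direction. Nothing measured here accounts for this reversal.

The compounds shown leave open what an ethyl or isopropyl group on the same amine nitrogen would give, and so whether the number climbs step by step from methyl to tert-butyl or jumps only at tert-butyl. A plain amino group, with hydrogen in place of methyl, is also an open case.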